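Replacing the amide link with a substituted phenyl

The source may report more compounds than this note shows. Statements on the series, on what has been measured and on what is new or still open speak of the compounds shown alone.

Compound 1: `CCCCCCCCOC1CC(=O)Nc2c1c(C)nn2-c1ncnc2nc[nH]c12` — 388 nM
Compound 2: `Cc1nn(-c2ncnc3nc[nH]c23)c2c1C(NC(=O)c1ccccc1)CC(=O)N2` — 158 nM

Among the measured compounds shown here, in a functional assay on HEK293 cells for agonist activity at G-protein coupled receptor 39 (Homo sapiens), read by scintillation proximity assay and inositol phosphate accumulation, with a stated time of 75 min (a lower number here means that less compound is needed, a higher number that more compound is needed for the effect), compound 1 gives 388 nM and compound 2 gives 158 nM, so compound 2 holds the lower of the two numbers, the single measured step being a 2.5-fold lower number from compound 1 to compound 2 (0.39 log units; beyond the scatter). Compound 3, `Cc1nn(-c2ncnc3nc[nH]c23)c2c1C(c1ccc(F)cc1Cl)CC(=O)N2`, carries 2-chloro-4-fluorophenyl in place of benzamido on a saturated ring carbon. For the measured compounds named here, no measured step exchanges one group on that carbon for a group of this kind; the one step shows only that what sits there shifts this assay by a modest amount. The change is therefore expected to register as a 1.3-fold lower number from compound 2 to compound 3 (0.12 log units; within the scatter). Compound 3 is estimated at 120 nM, within 30 nM to 500 nM.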

Compound 3, half-maximal effective concentration: 280 nM
The estimate for compound 3 lay 2.3-fold (0.37 log units) below the measured number, within the range that was stated.
By their numbers in this assay, from the lowest: compounds 2, 3 and 1 (each within the scatter of the next, the first and the last beyond it).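

With no hydrogen-bond donor or acceptor, 2-chloro-4-fluorophenyl on this saturated ring carbon gives a number within the scatter of benzamido (a 1.8-fold higher number from compound 2 to compound 3 (0.25 log units; within the scatter)) and of octyloxy (a 1.4-fold lower number from compound 1 to compound 3 (0.14 log units; within the scatter)). An aromatic ring attached directly to this carbon, without the amide link, therefore remains compatible with agonist activity at this level. No available evidence accounts for this result. From the compounds shown here alone, whether a plain phenyl would give a similar number remains open, leaving the contribution of the chlorine and fluorine unresolved. Going by these compounds, an amine or a carboxylic acid on this carbon also remains untested here.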